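The source may report more compounds than this note shows. Statements on the series, on what has been measured and on what is new or still open speak of the compounds shown alone.

Compound 3, `COc1cc2ncnc(Nc3cccc(Cl)c3F)c2cc1OCCCCC(=O)Nc1ccc(S(N)(=O)=O)cc1`, gives 5560 nM in a functional assay on A-431 cells (Homo sapiens) for antiproliferative activity, read by MTT assay, with a stated time of 72 h; on this read-out higher numbers stand for weaker inhibition and lower numbers for stronger inhibition. Among the three measured compounds its number sits at the low end: compound 1, `COc1cc2ncnc(Nc3ccc(Br)cc3)c2cc1OCCCCC(=O)Nc1ccc(S(N)(=O)=O)cc1`, with 6570 nM, is within the scatter of it, as the step of a 1.2-fold lower number from compound 1 to compound 3 (0.07 log units; within the scatter) shows, while compound 2, `COc1ccc(Nc2ncnc3cc(OC)c(OCCCCC(=O)Nc4ccc(S(N)(=O)=O)cc4)cc23)cc1OC`, with 35400 nM, lies clearly apart, the step of a 6.4-fold lower number from compound 2 to compound 3 (0.80 log units; beyond the scatter) being beyond the scatter. The step of a 5.4-fold higher number from compound 1 to compound 2 (0.73 log units; beyond the scatter) likewise falls beyond the scatter.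

Compound 4, `COc1cc2ncnc(Nc3ccc(OC(F)(F)F)cc3)c2cc1OCCCCC(=O)Nc1ccc(S(N)(=O)=O)cc1`, differs from compound 3 in the change (4-(trifluoromethoxy)phenyl in place of 3-chloro-2-fluorophenyl on a nitrogen on an aromatic ring). All three measured steps vary the same aryl group on that nitrogen, so all of them bear on it. Exchanging 4-bromophenyl for 3-chloro-2-fluorophenyl moved the number only within the scatter, whereas 3,4-dimethoxyphenyl raised it modestly. A 4-(trifluoromethoxy)phenyl group is a single-substituent aryl like 4-bromophenyl, so for compound 4 a step of about a 1.3-fold higher number from compound 3 to compound 4 (0.10 log units; within the scatter) in this assay is expected, small and at most slightly upward. Compound 4 is therefore estimated at 7000 nM, in the range 2500 nM to 20000 nM.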

Compound 4, half-maximal inhibitory concentration: 22500 nM
Compound 4: the middle estimate sits 3.2-fold (0.51 log units) below what was measured; the measured number lies above the stated range.
By their numbers in this assay, from the lowest: compounds 3 and 1 (each within the scatter of the next); then compounds 4 and 2 (each within the scatter of the next).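

In this assay, going by these compounds alone, the aryl group on this nitrogen proves less tolerant of change than the earlier compounds indicated: trifluoromethoxy in place of bromo on an aromatic carbon, a change in one substituent only, gives a 3.4-fold higher number from compound 1 to compound 4 (0.53 log units; beyond the scatter) and the exchange of the 3-chloro-2-fluorophenyl group gives a 4.0-fold higher number from compound 3 to compound 4 (0.61 log units; beyond the scatter) as well. Having one substituent therefore does not keep 4-(trifluoromethoxy)phenyl level with 4-bromophenyl, and a 1.6-fold lower number from compound 2 to compound 4 (0.20 log units; within the scatter) instead puts it within the scatter of the 3,4-dimethoxyphenyl group. Nothing measured here accounts for this difference between the groups.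

As far as these compounds go, it remains open whether a trifluoromethyl group or a nitrile in place of the bromo would stay with compound 1 or fall with compound 4. From the compounds shown here alone, it is also open whether the same gap between these aryl groups would hold with a longer chain on the shared core.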